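The source may hold more compounds than are shown below. What is called first, only, known or untested is meant among the compounds shown, and "the series" means these compounds.

Working notes on the dithiocarbamate-type series tested in a functional assay on MDA-MB-231 cells (Homo sapiens) for antiproliferative activity, read by MTT assay, with a stated time of 72 h; on this read-out lower numbers stand for stronger inhibition and higher numbers for weaker inhibition.

Of the compounds shown here, three have numbers so far. Compound 1 `CCC(C)SSC(=S)N(CC)CC` gives 6000 nM in this assay. Compound 2 `S=C(SSC1CCCCC1)N1CCCC1` gives 4700 nM in this assay, and compound 3 `CCCCSSC(=S)N1CCCCC1` gives 8000 nM in this assay. Compound 1 holds the second highest number of the three, and both its neighbours sit within the scatter of it, compound 2 on the lower side and compound 3 on the higher side, so no order can be read among them. No pair among these three differs in a single place, so none of the gaps can be tied to one structural change.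

Compound 4 `CCN(CC)C(=S)SSCCO` is not yet measured. Against compound 1 it differs as follows: 2-hydroxyethyl in place of sec-butyl on a sulfur. Nothing measured here tells what a 2-hydroxyethyl in place of sec-butyl does, and the three numbers in hand spread only within the scatter of one another. The expectation for compound 4 is a step of a 1.5-fold higher number from compound 1 to compound 4 (0.18 log units; within the scatter) toward a somewhat higher number, and it may well fall within the scatter. The estimate for compound 4 in this assay is 9000 nM, with a range from 3500 nM to 23000 nM.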

Compound 4, half-maximal inhibitory concentration: 10000 nM
Beside the measured number, compound 4's estimate is 1.1-fold (0.05 log units) below it; the range from low to high includes it.
By their numbers in this assay, from the lowest: compounds 2, 1, 3 and 4 (each within the scatter of the next, the first and the last beyond it).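

For the compounds shown here, this is the first comparison that isolates a single change: 2-hydroxyethyl in place of sec-butyl on a sulfur whose other neighbours are sulfur. In this assay the step is a 1.7-fold higher number from compound 1 to compound 4 (0.22 log units; within the scatter), so bringing in a hydrogen-bond donor and acceptor at this place gives no shift that can be claimed, and compound 4 stays in the same band of numbers as compound 1. No measured property bears on this result.

As far as these compounds go, whether a carboxylic acid, an amine or a longer chain on this sulfur would read any differently remains open. Also open, from the compounds shown here alone, is whether the same exchange would read alike on the cores of compound 2 and compound 3.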